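The source may report more compounds than this note shows. Statements on the series, on what has been measured and on what is new or still open speak of the compounds shown alone.

For the measured compounds named here, in a functional assay on MCF7 cells (Homo sapiens) for inhibition, read by MTT assay, with a stated time of 48 h (on this read-out lower numbers stand for stronger inhibition and higher numbers for weaker inhibition), compound 1 (`Brc1ccc2[nH]cc(C(c3ccc4ccccc4c3)c3c[nH]c4ccc(Br)cc34)c2c1`) gives 7100 nM, while compound 2 (`Clc1ccc(C(c2c[nH]c3ccc(Br)cc23)c2c[nH]c3ccc(Br)cc23)cc1`) gives 3500 nM, the lower of the two numbers measured so far. Compound 3 (`O=[N+]([O-])c1ccc(C(c2c[nH]c3ccc(Br)cc23)c2c[nH]c3ccc(Br)cc23)cc1`) has not yet been measured. It keeps everything in compound 2 except one group, with nitro in place of chloro on an aromatic carbon. Going by the values given here, only one measured step is available, a 2.0-fold lower number from compound 1 to compound 2 (0.31 log units; beyond the scatter). That modest step put 4-chlorophenyl in place of naphthalen-2-yl, so it bears only loosely on the new change. Among the compounds with values here, no measured pair shows what swapping chloro for nitro does here. In this assay, therefore, no step beyond the scatter is expected, and neither direction is favoured. The estimated step is a 1.2-fold lower number from compound 2 to compound 3 (0.07 log units; within the scatter). For compound 3, the expected value is 3000 nM, with an estimated range from 1000 nM to 9000 nM.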

Compound 3, half-maximal inhibitory concentration: 3100 nM
Compound 3: middle estimate off by 1.0-fold (0.01 log units), on the low side; the measured number falls inside the stated range.
By their numbers in this assay, from the lowest: compounds 3 and 2 (each within the scatter of the next); then compound 1.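

In this assay, this position, para to a large group, tolerates a clear change in the substituent: replacing chloro with nitro swaps a single chlorine for three heavy atoms and adds hydrogen-bond acceptors, yet gives only a 1.1-fold lower number from compound 2 to compound 3 (0.05 log units; within the scatter). Against naphthalen-2-yl, 4-nitrophenyl gives a 2.3-fold lower number from compound 1 to compound 3 (0.36 log units; beyond the scatter), so the earlier shift seen with 4-chlorophenyl now recurs with a second substituted phenyl group. No evidence is available to explain why chloro and nitro read alike here.

From the compounds shown here alone, with only these two groups at this position, it remains open whether an amine or a carboxylic acid there would also leave the number within the scatter. Going by these compounds, it is equally open whether a plain hydrogen at this position would match chloro and nitro.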